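This account rests on a few compounds, and the source may have more. Where it says the series, first, only, none or still open, it means among the compounds named here.

Measured so far:
- compound 1, `Nc1nc(O)nc2c1nc(O)n2Cc1ccccc1`: 0.1 uM
- compound 2, `Nc1ncnc2c1nc(O)n2Cc1ccc(Cl)cc1`: 10 uM

Both numbers come from a functional assay (spleen, spleen) for activation, with Mus musculus as the target; a lower number here means that less compound is needed, a higher number that more compound is needed for the effect. Among the two values, compound 1 gives the lowest number; compound 2 gives a higher number, a gap well beyond the usual scatter. The two structures differ in more than one place, so nothing can be read from them about any single change.

The unmeasured compound 3, `CCCC[S+]([O-])c1nc(N)c2nc(O)n(Cc3ccccc3)c2n1`, differs from compound 1 in one place: a group of 6 heavy atoms (4 carbon, 1 oxygen, 1 sulfur; no ring) in place of one oxygen atom, on an aromatic carbon. Going by the values given here, no pair of measured compounds shows what such a change does, so the expectation rests on the change itself, a large group in place of a small one. A weakening of moderate size is expected, the step from compound 1 to compound 3 in this assay being estimated at a 10-fold higher number from compound 1 to compound 3 (1.00 log units; beyond the scatter). Compound 3 is expected to give about 1 uM, within a range from 0.1 uM to 10 uM.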

Compound 3, minimum effective concentration: 0.01 uM
For compound 3 the middle estimate is 100-fold (2.00 log units) above the measured one, outside the stated range (below it).
By their numbers in this assay, from the lowest: compound 3; then compound 1; then compound 2.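

At the aromatic carbon between two ring nitrogen atoms, this assay tolerates far more than the small hydroxy group: putting a group of 6 heavy atoms there gives a 10-fold lower number from compound 1 to compound 3 (1.00 log units; beyond the scatter). The hydroxy group has 1 hydrogen-bond donor and the entering group has 0, so in this pair a low number does not depend on a donor at this place. Nothing available explains why the larger group lowers the number.

This single step cannot separate the roles of the sulfur, its oxygen and the four-carbon chain. As far as these compounds go, it remains open how a plain butyl chain, a butylthio group without the oxygen, a longer chain or an amine would behave at the same place.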